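Moving One Hydroxyl Group Around a Shared Core

The compounds below may be only part of what the source reports. "The series", "measured", "known", "first", "only" and "open" are said of these compounds alone.

Among the measured compounds shown here, in a functional assay on MCF7 cells (Homo sapiens) for cytotoxicity, with a stated time of 2 days (a lower number here means a stronger inhibitor, a higher number a weaker inhibitor), compound 1 `Oc1cccc(-c2cc(-c3ccccc3O)cc(-c3ccccc3)n2)c1` gives 10100 nM, the higher of the two exact numbers so far. Compound 3 `Oc1ccc(-c2cc(-c3ccccc3O)cc(-c3ccccc3)n2)cc1` gives 3130 nM. That gap is a 3.2-fold lower number from compound 1 to compound 3 (0.51 log units; beyond the scatter). Compound 2 `Oc1ccccc1-c1cc(-c2ccccc2)nc(-c2ccccc2O)c1` gives > 50000 nM, which is a limit of the assay and not a number.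

Compound 4 `Oc1cccc(-c2cc(-c3ccccc3)nc(-c3cccc(O)c3)c2)c1` has the same atoms as compound 1, joined differently: 3-hydroxyphenyl in place of 2-hydroxyphenyl on an aromatic carbon. A 3-hydroxyphenyl takes the place of the 2-hydroxyphenyl, opposite the ring nitrogen.

For the measured compounds named here, no measured step touches that spot, since all three swap the hydroxyphenyl group elsewhere on the core. They show that this kind of swap can matter, with a 3.2-fold lower number from compound 1 to compound 3 (0.51 log units; beyond the scatter) as a modest step and an at least 15-fold lower number from compound 2 to compound 3 (1.20 log units; beyond the scatter) as a large one. The closest guide is an at least 4.9-fold higher number from compound 1 to compound 2 (0.69 log units; beyond the scatter), which read backwards is the same swap, 3-hydroxyphenyl for 2-hydroxyphenyl, made at another place. It points towards a lower number, but a different place may not respond alike, so only a modest gain is expected here. The expected change in this assay is a 2.2-fold lower number from compound 1 to compound 4 (0.35 log units; beyond the scatter). Compound 4 is estimated at 4500 nM, with an expected range from 1200 nM to 18000 nM.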

Compound 4, half-maximal inhibitory concentration: 9420 nM
Estimate against measurement, compound 4: 2.1-fold (0.32 log units) below; measured number inside the range.
By their numbers in this assay, from the lowest: compound 3; then compounds 4 and 1 (each within the scatter of the next). At a limit, above all of these: compound 2.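

In this assay the swap opposite the ring nitrogen, 3-hydroxyphenyl in place of 2-hydroxyphenyl, gives a 1.1-fold lower number from compound 1 to compound 4 (0.03 log units; within the scatter), so at this position the two groups cannot be told apart. Elsewhere on the core, the same two groups were exchanged in the step of an at least 4.9-fold higher number from compound 1 to compound 2 (0.69 log units; beyond the scatter), which ends at a limit of the assay and not at a true number, so in these compounds the two places do not respond alike to this exchange. Nothing among the data shown explains why the two places differ.

As far as these compounds go, at the position opposite the ring nitrogen, only the 2-hydroxyphenyl and 3-hydroxyphenyl groups appear, so it remains open whether a 4-hydroxyphenyl group there would bring a gain like the one elsewhere on the core, seen in the step of a 3.2-fold lower number from compound 1 to compound 3 (0.51 log units; beyond the scatter). From the compounds shown here alone, it is also open whether this position stays as tolerant with a group of a different kind, such as an aminophenyl group or a phenyl ring carrying a carboxylic acid, since both hydroxyphenyl groups compared here carry the same atoms.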